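The source may hold more compounds than are shown below. What is called first, only, known or untested is meant among the compounds shown, and "the series" means these compounds.

Measured compounds:
- compound 1 `COc1ccc(C2=NN(C3=NC(=O)/C(=C4\C(=O)Nc5ccc(Cl)cc54)S3)C(c3ccc(OC)cc3)C2)cc1` gives 230 nM
- compound 2 `O=C1N=C(N2N=C(c3ccccc3)CC2c2ccc(Cl)cc2)S/C1=C1/C(=O)Nc2ccccc21` gives 230 nM
- compound 3 `COc1ccc(-c2cc(-c3ccc(Cl)cc3)n(C3C(=O)Nc4ccc(Br)cc43)n2)cc1` gives 9750 nM

All three were run in a functional assay on cells (Cancer cell lines, Homo sapiens) for cytotoxicity, read by sulforhodamine B assay, with a stated time of 48 h; a higher number here means a weaker inhibitor of growth, a lower number a stronger inhibitor of growth. Compound 3 stands at the highest number of the three; its gap to compound 1 and its gap to compound 2 are each beyond the scatter, so compound 3 is the weakest growth inhibitor in this set. Compound 1 and compound 2 lie within the scatter of each other, and nothing is said here about an order between them.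

Compound 4 `COc1ccc(-c2cc(-c3ccc(Cl)cc3)n(C3C(=O)Nc4ccc(Cl)cc43)n2)cc1` is not yet measured. It differs from compound 3 in a single place: chloro in place of bromo on an aromatic carbon. The core, the two aryl groups on the five-membered ring and the fused lactam are unchanged; only the halogen on the outer six-membered ring is swapped.

For the measured compounds named here, no measured pair in the set isolates a bromo-to-chloro exchange, so no step of this kind is known here. From the small size of the change, the expectation in this assay is a step of no more than the scatter, in either direction, with the number for compound 4 staying near that of compound 3. The estimated step is a 1.1-fold lower number from compound 3 to compound 4 (0.03 log units; within the scatter), which is expected to be none beyond the scatter. For compound 4 the expected value is 9000 nM, with a range from 4000 nM to 20000 nM.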

Compound 4, concentration for 50% growth inhibition: 3680 nM
Compound 4: middle estimate off by 2.4-fold (0.39 log units), on the high side; the whole stated range lies above it.
By their numbers in this assay, from the lowest: compounds 1 and 2 (each within the scatter of the next); then compound 4; then compound 3.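

In this assay, exchanging bromo for chloro on this aromatic carbon of the fused system gives a 2.6-fold lower number from compound 3 to compound 4 (0.42 log units; beyond the scatter), so a single halogen swap at this position moves the read-out by a modest step beyond the scatter. For the compounds shown here, this is the first comparison that isolates one place, because compounds 1, 2 and 3 differ from one another in several places at once and could say nothing about this position alone. The data shown offer no measurement that explains why chloro gives the lower number here.

As far as these compounds go, only these two halogens are compared at this position, so it remains open whether fluoro, a methoxy group, an amine or a carboxylic acid on the same carbon would continue this direction, reverse it or leave the number unchanged. From the compounds shown here alone, it also remains open whether the same bromo-to-chloro exchange would give a step of similar size and direction on the core of compound 1 or compound 2, or whether it holds only on the core shared by compound 3 and compound 4.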